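A few compounds are considered here, and "the series" means these few. Any claim that something is new, unique, unknown or untested is made for them only; others in the source may bear on it.

Measured in a functional assay on SK-MEL-28 cells (Homo sapiens) for cytotoxicity, read by MTT assay, with a stated time of 72 h; on this read-out lower numbers stand for stronger inhibition and higher numbers for weaker inhibition:
- compound 1 `CSc1nc(Br)c(C(=O)c2ccccc2)s1`: > 100000 nM (a limit)
- compound 2 `CCOC(=O)c1sc(N2CCCC2)nc1Cl`: 82000 nM
- compound 3 `N#Cc1sc(N2CCCC2)nc1Cl`: > 100000 nM (a limit)

Compound 1 stands at > 100000 nM in this assay, which is a limit and not a number. Compound 4 `O=C(c1ccccc1)c1sc(N2CCCCC2)nc1Br` has piperidin-1-yl in place of methylsulfanyl on an aromatic carbon. Among the measured compounds shown here, no measured step tests this exchange. The only one, an at least 1.2-fold higher number from compound 2 to compound 3 (0.08 log units; that floor lies within the scatter), concerns another group, and its floor lies within the scatter. For the measured compounds named here, compound 2 and compound 3 also carry a ring amine rather than methylsulfanyl, and compound 2 gives 82000 nM, the only number in the set. Only a small step towards a lower number is therefore expected. The estimated change is an at least 1.6-fold lower number from compound 1 to compound 4 (0.22 log units; that floor lies within the scatter). Compound 4 is estimated at 60000 nM, with an expected range of 15000 nM to 100000 nM.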

Compound 4, half-maximal inhibitory concentration: 91000 nM
For compound 4 the middle estimate is 1.5-fold (0.18 log units) below the measured one; low and high end bracket the measured number.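

In this assay compound 1 stands at > 100000 nM, which is a limit and not a number. With piperidin-1-yl in place of methylsulfanyl on the aromatic carbon next to the ring nitrogen and the ring sulfur, compound 4 gives a measurable number (91000 nM). As far as these compounds go, the change is an at least 1.0-fold lower number from compound 1 to compound 4 (0.04 log units; that floor lies within the scatter) and so shows no real gain, and its full size stays unknown: the limit of > 100000 nM in this assay, at which 2 of the 4 values shown sit.

Open, from the compounds shown here alone, is whether an open-chain amine such as dimethylamino, or piperazin-1-yl, on this carbon would give a clearly lower number.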